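The source may report more compounds than this note shows. Statements on the series, on what has been measured and on what is new or still open speak of the compounds shown alone.

The three measured compounds:
Compound 1, `O=C(CSc1nc(Nc2ccccc2)c2ccccc2n1)Nc1ccccc1Cl`: in a functional assay on MDA-MB-231 cells (Homo sapiens) for inhibition, read by MTT assay, with a stated time of 72 h (a higher number here means a weaker inhibitor, a lower number a stronger inhibitor), compound 1 gives 24400 nM.
Compound 2, `O=C(CSc1nc(Nc2ccccc2)c2ccccc2n1)Nc1ccccc1Br`: in this assay compound 2 gives 14100 nM.
Compound 3, `O=C(CSc1nc(Nc2ccccc2)c2ccccc2n1)Nc1ccc(C(F)(F)F)cc1`: in this assay compound 3 gives 11100 nM.

Compound 2 holds the second-highest of these three numbers in this assay. Compound 3 lies nearest to it, with a 1.3-fold lower number from compound 2 to compound 3 (0.10 log units; within the scatter), and compound 1 furthest, with a 1.7-fold lower number from compound 1 to compound 2 (0.24 log units; within the scatter); neither gap goes beyond the usual scatter, so the three compounds are hardly told apart.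

Compound 4, `CCc1ccc(NC(=O)CSc2nc(Nc3ccccc3)c3ccccc3n2)cc1`, is compound 2 with a single change: 4-ethylphenyl in place of 2-bromophenyl on an amide-type nitrogen. Two measured steps alter this same part of the molecule. Swapping 2-chlorophenyl for 4-(trifluoromethyl)phenyl on the amide-type nitrogen gave a 2.2-fold lower number from compound 1 to compound 3 (0.34 log units; beyond the scatter), a modest gain, while the corresponding swap from 2-bromophenyl gave a 1.3-fold lower number from compound 2 to compound 3 (0.10 log units; within the scatter), which stays within the scatter. Within the data shown here, no measured step covers an ethyl group, so the evidence is thin. On what the data show, only a small lowering of the number at most is expected, with an estimated step of a 1.3-fold lower number from compound 2 to compound 4 (0.11 log units; within the scatter). Compound 4 is therefore expected to give about 11000 nM in this assay, somewhere between 4500 nM and 27000 nM.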

Compound 4, half-maximal inhibitory concentration: 33900 nM
Compound 4: the middle estimate sits 3.1-fold (0.49 log units) below what was measured, and the stated range ends below it.
By their numbers in this assay, from the lowest: compounds 3, 2, 1 and 4 (each within the scatter of the next, the first and the last beyond it).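

In this assay, the group on the amide-type nitrogen now shows a change that clearly raises the number, where earlier steps at this place either lowered it or stayed within the scatter: 4-ethylphenyl in place of 2-bromophenyl gives a 2.4-fold higher number from compound 2 to compound 4 (0.38 log units; beyond the scatter) and ethyl in place of trifluoromethyl gives a 3.1-fold higher number from compound 3 to compound 4 (0.48 log units; beyond the scatter) so both steps lie beyond the scatter. The second step also shows that two groups sharing the name pattern of a 4-substituted phenyl need not read alike, which means the earlier gain with 4-(trifluoromethyl)phenyl does not carry over to every group of that kind. Against 2-chlorophenyl the same swap gives a 1.4-fold higher number from compound 1 to compound 4 (0.14 log units; within the scatter) and that pair cannot be told apart, and no measurement shown gives a reason for any of these differences.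

Each ring on this nitrogen carries only one halogen, trifluoromethyl or ethyl group, so 2-ethylphenyl and 4-bromophenyl would be needed to separate the effect of the group from where it sits on the ring. From the compounds shown here alone, it also remains open how this series would read with a longer chain such as butyl, or with an amine or a carboxylic acid on the same ring.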